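Methyl for chloro on a benzoxazole core: compound 4 expected

The source may hold more compounds than are shown below. What is called first, only, known or untested is meant among the compounds shown, and "the series" means these compounds.

Compound 1 `CN(C)CCN1CCN(CC(=O)Nc2ccc(-c3nc4cc(Cl)ccc4o3)cc2)CC1` and compound 2 `Cc1ccc2oc(-c3ccc(NC(=O)CN4CCN(CCN(C)C)CC4)cc3)nc2c1` share a core and differ by methyl in place of chloro on an aromatic carbon. In a functional assay on MCF7 cells (Homo sapiens) for cytotoxicity, read by MTT assay, with a stated time of 24 h (on this read-out lower numbers stand for stronger inhibition and higher numbers for weaker inhibition), compound 1 gives 7920 nM, and compound 2 gives 23700 nM. The step of a 3.0-fold higher number from compound 1 to compound 2 (0.48 log units; beyond the scatter) is the only measured example of this change among the compounds shown. Compound 3 `Cc1cc(-c2nc3cc(Cl)ccc3o2)ccc1NC(=O)CCl` differs from compound 1 in more than one place, and the difference between the two cores is not broken down here. In this assay compound 3 is reported only as a limit, > 100000 nM, and it sits at the limit of > 100000 nM in this assay, at which 1 of the 3 values shown sits. Compound 4 `Cc1ccc2oc(-c3ccc(NC(=O)CCl)c(C)c3)nc2c1` is not yet measured; it differs from compound 3 by methyl in place of chloro on an aromatic carbon, the same change made from compound 1 to compound 2. Compound 4 is expected to remain at or beyond the limit, with an estimated step that the limit leaves unreadable from compound 3 to compound 4, because compound 3 already stands at the limit of > 100000 nM in this assay, at which 1 of the 3 values shown sits, and the earlier step of a 3.0-fold higher number from compound 1 to compound 2 (0.48 log units; beyond the scatter) moved toward higher numbers. The estimate for compound 4 in this assay is 200000 nM, with a range of 100000 nM to 600000 nM.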

Compound 4, half-maximal inhibitory concentration: 96500 nM
The estimate for compound 4 lay 2.1-fold (0.32 log units) above the measured number; the whole stated range lies above it.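

In this assay, methyl in place of chloro on an aromatic carbon gives an at least 1.0-fold lower number from compound 3 to compound 4 (0.01 log units; that floor lies within the scatter). Set beside the earlier example, the same change does not carry over from one core to the other as a fixed step: the same change on two cores in this assay, a 3.0-fold higher number (0.48 log units; beyond the scatter) from compound 1 to compound 2 and an at least 1.0-fold lower number (0.01 log units; that floor lies within the scatter) from compound 3 to compound 4, at least 3.1-fold (0.49 log units) apart, beyond the scatter of two such steps Two pairs give no rule for other cores, and the true size of the newer step stays open, since compound 3 is reported only as a limit: the limit of > 100000 nM in this assay, at which 1 of the 4 values shown sits.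

The compounds shown do not tell which of the differences between the two cores goes with the gap between the steps, and no pair here separates those differences one at a time. Among these compounds, they also leave open how a fluoro, a methoxy or a nitrile in place of the chloro would read in this assay, and whether the change would behave the same way on a core carrying an amine chain other than the one in compound 1.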